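Swapping the Aryl Group on the Ring Amine Nitrogen

The source may report more compounds than this note shows. Statements on the series, on what has been measured and on what is new or still open speak of the compounds shown alone.

Measured compounds:
Compound 1, `COC(=O)C1=C(C)N=C(C)/C(=C(/O)OC)C1c1cccc(N/C(=N/CCNC2CCN(c3ccccc3OC(F)(F)F)CC2)NC#N)c1`: in an assay on SK-N-MC cells for inhibition of Neuropeptide Y receptor type 1 (Homo sapiens) (a higher number here means a weaker inhibitor, a lower number a stronger inhibitor), compound 1 gives 28 nM.
Compound 2, `COC(=O)C1=C(C)N=C(C)/C(=C(/O)OC)C1c1cccc(N/C(=N/CCNC2CCN(c3ccccc3O)CC2)NC#N)c1`: in this assay compound 2 gives 5 nM.

For the measured compounds named here, the only measured step is a 5.6-fold lower number from compound 1 to compound 2 (0.75 log units; beyond the scatter), so compound 2 stands lowest of the two numbers, and its nearest neighbour is the higher value of compound 1.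

Compound 3, `COC(=O)C1=C(C)N=C(C)/C(=C(/O)OC)C1c1cccc(N/C(=N/CCNC2CCN(c3cccc(Cl)c3)CC2)NC#N)c1`, carries the change (3-chlorophenyl in place of 2-hydroxyphenyl on an amine nitrogen in a ring). The step from compound 1 to compound 2 bears on this only in part: it shows that the group on the aromatic ring attached to the amine nitrogen in a ring matters beyond the scatter, but neither measured compound carries a chlorine in place of the oxygen-bearing group, and the hydroxy group that gave the lower number in compound 2 is absent in compound 3. Compound 3 is therefore expected to move back toward, or somewhat past, the number of compound 1, a step of a 5.0-fold higher number from compound 2 to compound 3 (0.70 log units; beyond the scatter).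

Compound 3 is estimated at 25 nM, with a range from 8 nM to 80 nM.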

Compound 3, half-maximal inhibitory concentration: 8 nM
The estimate for compound 3 lay 3.1-fold (0.49 log units) above the measured number; low and high end bracket the measured number.
By their numbers in this assay, from the lowest: compounds 2 and 3 (each within the scatter of the next); then compound 1.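

In this assay, 3-chlorophenyl in place of 2-hydroxyphenyl on the amine nitrogen in a ring gives a 1.6-fold higher number from compound 2 to compound 3 (0.20 log units; within the scatter) and so shows that the hydroxy group is not needed for a number at this level, as the entering group counts no hydrogen-bond donors or acceptors. Measured against 2-(trifluoromethoxy)phenyl, the same group gives a 3.5-fold lower number from compound 1 to compound 3 (0.54 log units; beyond the scatter) and thus leaves compound 1 alone among the three as the compound set apart by this position. Nothing measured here accounts for either step.

The compounds shown leave open how much the chlorine itself contributes, as the change from compound 2 to compound 3 alters both the group and where it sits on the aromatic ring. They also leave open what an unsubstituted phenyl group, or a carboxylic acid on that ring, would give.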